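Cytotoxicity in Vero Cells: Swapping the Aryl Amide

A few compounds are considered here, and "the series" means these few. Any claim that something is new, unique, unknown or untested is made for them only; others in the source may bear on it.

Compound 1 `CCCCNC(=O)Nc1cc2nc(C3CCCCC3)[nH]c2cc1N(CC)CC`: > 100 ug/mL
Compound 2 `CN(C)c1cc2[nH]c(C3CCCCC3)nc2cc1NC(=O)c1ccc(F)cc1F`: > 100 ug/mL
Compound 3 `CCCc1ccc(C(=O)Nc2cc3nc(C4CCCCC4)[nH]c3cc2N(CC)CC)cc1`: "not determined" (no result reported)

In an ADME assay on Vero cells (Chlorocebus sabaeus) for cytotoxicity, read by resazurin assay, with a stated time of 3 days (a lower number here means a stronger inhibitor, a higher number a weaker inhibitor), compound 1 reaches only the limit of the assay, > 100 ug/mL, not a number. Compound 2 likewise stops at the limit, > 100 ug/mL. Compound 3 has no result in this assay, so it stands nowhere on these numbers; the two values beside it are both limits (the limit of > 100 ug/mL in this assay, at which 2 of the 3 values shown sit). Compound 4 `CCN(CC)c1cc2[nH]c(C3CCCCC3)nc2cc1NC(=O)c1ccc(F)cc1F` differs from compound 3 by 2,4-difluorophenyl in place of 4-propylphenyl on a carbonyl carbon. Among the measured compounds shown here, no measured step exists for comparison, so no change beyond the scatter in this assay is expected, and compound 2 already carries this same 2,4-difluorophenyl on a carbonyl carbon while sitting at the limit (the limit of > 100 ug/mL in this assay, at which 2 of the 3 values shown sit). Compound 4 is therefore expected to give 100 ug/mL, with a range from 50 ug/mL to 200 ug/mL, most likely again as a limit.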

Compound 4, half-maximal inhibitory concentration: > 100 ug/mL
Compound 4: a limit, no number; the forecaster's own chance of this, stated with the estimate: 80%; the middle value sits exactly at the limit.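

No step can be read between compound 4 and compound 1 or compound 2, as all three values are limits, not numbers: the limit of > 100 ug/mL in this assay, at which 3 of the 4 values shown sit.

The compounds shown leave open whether diethylamino in place of dimethylamino, or 2,4-difluorophenyl in place of butylamino, changes the result in this assay at all.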